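Replacing the Phenyl of Compound 3 with a Shorter Chain

A few compounds are considered here, and "the series" means these few. Any claim that something is new, unique, unknown or untested is made for them only; others in the source may bear on it.

Of the compounds shown here, three have been tested in a functional assay on the whole organism with Rattus norvegicus as the target; on this read-out higher numbers stand for an effect only at larger amounts of compound and lower numbers for an effect already at smaller amounts. Compound 1 `Nc1nc2ccc(OC(F)(F)C(F)(F)F)cc2s1` gives 2.5 mg/kg in this assay. Compound 2 `Nc1nc2cccc(OC(F)(F)F)c2s1` reaches only a limit of the assay, giving > 10 mg/kg in this assay. Compound 3 `N=c1sc2cc(OC(F)(F)F)ccc2n1Cc1ccccc1` likewise stands at a limit, giving > 10 mg/kg in this assay. Compound 3 therefore has no number of its own: its result sits at the limit of > 10 mg/kg in this assay, at which 2 of the 3 values shown sit. Only compound 1 carries a measured dose.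

Compound 4 `C[S+]([O-])Cn1c(=N)sc2cc(OC(F)(F)F)ccc21` is not yet measured and differs from compound 3 by a group of 3 heavy atoms (1 carbon, 1 oxygen, 1 sulfur; no ring) in place of a group of 6 heavy atoms (6 carbon; one six-membered aromatic ring of carbon only), on a saturated chain carbon bound to an aromatic nitrogen. For the measured compounds named here, no step between two measured compounds exists here that would show what such a change does in this assay, and the only result for compound 3 is a limit. The step expected for this change is a number no higher from compound 3 to compound 4 (the limit leaves the size open), resting on the limit of compound 3 alone and pointing in no direction that the present data could support. For compound 4 the estimated result in this assay is 10 mg/kg, with an expected range from 4 mg/kg to 30 mg/kg, and a substantial chance that the measurement again returns only a limit.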

Compound 4, dose for half-maximal effect: 2.3 mg/kg
Estimate against measurement, compound 4: 4.3-fold (0.64 log units) above; the whole stated range lies above it.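

In this assay, for the compounds shown here, the change on a saturated chain carbon bound to an aromatic nitrogen gives an at least 4.3-fold lower number from compound 3 to compound 4 (0.63 log units; beyond the scatter), the first single-place step and one that lies beyond the scatter. It shows that this position responds to substitution, and that the phenyl is not required there for an effect at a measurable dose, since compound 4, with its group of 3 heavy atoms and no ring, gives 2.3 mg/kg. The true size of the step remains unknown, however, because the result for compound 3 is a limit and not a number: the limit of > 10 mg/kg in this assay, at which 2 of the 4 values shown sit.

The compounds shown leave open whether the lower number goes with the loss of the phenyl or with the group that enters, a question that a thioether, a sulfone or a plain propyl chain at the same place would help to settle. They also leave open whether the same change would give a step of similar size with a group other than trifluoromethoxy on the shared core, since this step rests on one pair of compounds.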